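The source may hold more compounds than are shown below. What is called first, only, known or untested is meant among the compounds shown, and "the series" means these compounds.

Measured compounds:
Compound 1 `NC(=O)c1c(NC(=O)c2ccccc2Cl)sc2c1CCN(Cc1ccccc1Cl)C2`: 27500 nM
Compound 2 `NC(=O)c1c(NC(=O)c2ccc(C(F)(F)F)cc2)sc2c1CCN(Cc1c(Cl)cccc1Cl)C2`: > 50000 nM

Within the data shown here, in a functional assay on HeLa cells (Homo sapiens) for antiproliferative activity, with a stated time of 24 h (on this read-out higher numbers stand for weaker inhibition and lower numbers for stronger inhibition), compound 1 gives 27500 nM, and this is the only actual number in the set. Compound 2 is recorded only at the limit of > 50000 nM in this assay, at which 1 of the 2 values shown sits, so it is a limit and not a number. Among the measured compounds shown here, compound 1 therefore stands alone as the one quantified value, and that value marks only weak inhibition on this read-out.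

Compound 3 `NC(=O)c1c(NC(=O)c2ccccc2Cl)sc2c1CCN(C(=S)Nc1ccccc1Br)C2` is not yet measured. It differs from compound 1 in one place: a group of 10 heavy atoms (7 carbon, 1 nitrogen, 1 sulfur, 1 bromine; one six-membered aromatic ring of carbon only) in place of a group of 8 heavy atoms (7 carbon, 1 chlorine; one six-membered aromatic ring of carbon only), on an amine nitrogen in a ring. For the measured compounds named here, no pair of measured compounds spans this change, so there is no measured step to lean on; the compound 2 limit concerns a different pair of groups and says nothing about this one.

With nothing to point either way, the step of a 1.1-fold higher number from compound 1 to compound 3 (0.04 log units; within the scatter) is expected to stay within the usual scatter, with no clear direction. Compound 3 is accordingly estimated at 30000 nM in this assay, with a plausible range from 8000 nM to 100000 nM, and a real chance that only a limit is returned.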

Compound 3, half-maximal inhibitory concentration: 24600 nM
The estimate for compound 3 lay 1.2-fold (0.09 log units) above the measured number; the range from low to high includes it.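

In this assay the change on the amine nitrogen in the ring gives a 1.1-fold lower number from compound 1 to compound 3 (0.05 log units; within the scatter), so the two readings cannot be told apart. Compound 1 alone could not show how this position responds to anything other than the 2-chlorobenzyl group; compound 3 shows that a larger group, with a double bond outside aromatic rings, a hydrogen-bond donor and a hydrogen-bond acceptor, still returns a quantified value of the same weak order in this cell assay. Nothing measured here explains this outcome, and no measured property of either group bears on it.

As far as these compounds go, both quantified values mark only weak inhibition, so it remains open whether any group at this position can give clearly stronger inhibition, for example a simple amine, a carboxylic acid or a longer chain in place of the aromatic ring. Compound 2 is recorded only as a limit, > 50000 nM, and since it differs from the other two compounds in more than one place, it settles nothing about this position.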